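A few compounds are considered here, and "the series" means these few. Any claim that something is new, unique, unknown or untested is made for them only; others in the source may bear on it.

Measured so far in a functional assay on NCI-H520 cells (Homo sapiens) for cytotoxicity; on this read-out higher numbers stand for weaker inhibition of growth and lower numbers for stronger inhibition of growth:
- Compound 1 `COc1ccc(C2=C(c3cc(OC)c(OC)c(OC)c3)CC3CCCN3C2=O)cc1O`: > 100000 nM
- Compound 2 `COc1ccc(C2=C(c3ccc(SC)cc3)CC3CCCN3C2=O)cc1OC(=O)C1CCCN1C(=O)OC(C)(C)C`: 5000 nM
- Compound 3 `CSc1ccc(C2=C(c3ccc(F)c(C)c3)C(=O)N3CCCC3C2)cc1`: 500 nM

Compound 1 gives > 100000 nM, which is a limit of the assay and not a number. That leaves two true numbers to compare. Compound 3 at 500 nM holds the lower of them, and compound 2 at 5000 nM sits higher by a gap beyond the usual scatter. Compound 3 therefore stands as the strongest inhibitor of growth among the three.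

Compound 4 `CSc1ccc(C2=C(c3ccc(C)cc3)C(=O)N3CCCC3C2)cc1` has not yet been measured. It carries 4-methylphenyl in place of 4-fluoro-3-methylphenyl on a double-bonded ring carbon, next to the ring atom that bears a 4-(methylsulfanyl)phenyl group (4-methylphenyl in place of 4-fluoro-3-methylphenyl on a double-bonded ring carbon). The rest of the structure stays as it is in compound 3.

Going by the values given here, no pair of measured compounds isolates this change, so the expectation starts from compound 3 at 500 nM and remains loose. In this assay the expected step is small and, if it shows at all, leans towards weaker inhibition of growth: a 1.6-fold higher number from compound 3 to compound 4 (0.20 log units; within the scatter). For compound 4 the estimate is 800 nM, with an expected range of 200 nM to 4000 nM.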

Compound 4, concentration for 50% growth inhibition: 900 nM
For compound 4 the middle estimate is 1.1-fold (0.05 log units) below the measured one; low and high end bracket the measured number.
By their numbers in this assay, from the lowest: compounds 3 and 4 (each within the scatter of the next); then compound 2. At a limit, above all of these: compound 1.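

In this assay, going by these compounds alone, the exchange on this double-bonded ring carbon gives the first step that can be read between two compounds differing in one place (the step is a 1.8-fold higher number from compound 3 to compound 4 (0.26 log units; within the scatter)), and it does not separate the two compounds. The 4-fluoro-3-methylphenyl group and the 4-methylphenyl group are therefore interchangeable at this position on this read-out, with the 4-(methylsulfanyl)phenyl group and the rest of the structure held constant; a single step on one pair, however, supports no wider pattern. Nothing in the data available here bears on why the step is this size.

The compounds shown keep a carbon-only aromatic ring at this position, so it remains open how the read-out would respond to a pyridine ring there, or to a phenyl ring carrying an amine or a carboxylic acid. Going by these compounds, it also remains open whether the same exchange would give a similar step with a group other than 4-(methylsulfanyl)phenyl on the neighbouring ring atom, such as a 4-methoxyphenyl group.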